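A few compounds are considered here, and "the series" means these few. Any claim that something is new, unique, unknown or untested is made for them only; others in the source may bear on it.

Compound 1 `COc1ccc(C(=O)CCc2ccc(OC)cc2OC)c(O)c1` was tested in an ADME assay on RAW264.7 cells (Mus musculus) for cytotoxicity, read by MTT assay, with a stated time of 24 h, tested at 5 ug/mL (a lower number here means a stronger effect, a higher number a weaker effect of the compound at the concentration tested), where compound 1 gives 87.4%. Compound 2 `COc1ccc(CCC(=O)c2ccc(OC)cc2O)cc1` is its nearest comparison: in this assay compound 2 gives 92.3%. For the measured compounds named here, the only step between measured compounds, a number 4.9 percentage points higher from compound 1 to compound 2 (within the scatter), corresponds to a hydrogen in place of methoxy on an aromatic carbon. Of the two numbers shown, compound 1 stands at the lower one, but since the gap to compound 2 lies within the scatter, the two readings cannot be told apart.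

Compound 3 `COc1ccc(C(=O)CCc2ccc(OC)c(OC)c2OC)c(O)c1` has not been measured. Its change from compound 1 is methoxy in place of hydrogen on an aromatic carbon. Going by the values given here, the one measured step that bears on this kind of change, a number 4.9 percentage points higher from compound 1 to compound 2 (within the scatter), runs in the opposite sense and stayed within the scatter, so it gives no sign that adding or removing a methoxy group moves the read-out. On that ground the step of a number 0.4 percentage points lower from compound 1 to compound 3 (within the scatter) is expected to amount to none beyond the scatter. For compound 3 in this assay the estimate is 87%, with a range from 76% to 97%.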

Compound 3, a percentage reported as activity, at one concentration (the size of the read-out at that concentration, not a potency): 94.8%
Beside the measured number, compound 3's estimate is 7.8 percentage points below it; low and high end bracket the measured number.
By their numbers in this assay, from the lowest: compounds 1, 2 and 3 (each within the scatter of the next).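

In this assay, a methoxy group in place of hydrogen on the aromatic carbon ortho to two methoxy groups and meta to a large group gives a number 7.4 percentage points higher from compound 1 to compound 3 (within the scatter). For the compounds shown here, this is the first reading for a group entering at this position, and it shows that this added methoxy, with its 2 heavy atoms and 1 hydrogen-bond acceptor, produces no change that can be separated from the scatter at the single concentration tested. The earlier step concerned a methoxy group leaving the core of compound 1, so the two steps together show that neither the loss of that methoxy group nor the gain of this one is distinguishable from repeat variation in this read-out, and nothing shown offers an explanation for the readings.

The compounds shown leave open whether any other group at this position, such as an amine, a carboxylic acid or a longer alkoxy chain, would shift the read-out beyond the scatter. They also leave open how these compounds would behave at other concentrations or exposure times, since every reading here is a single-concentration percentage and not a potency.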